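Trimming an alkyl group on a weakly inhibiting core

The source may report more compounds than this note shows. Statements on the series, on what has been measured and on what is new or still open speak of the compounds shown alone.

Compound 1 `CCCc1nc(C)c2c(C)nn(C)c(=O)n12` and compound 2 `CCCc1nc(C)c2c(C)nn(CC)c(=O)n12` share one core; compound 3 `Cc1nc(C(C)(C)C)n2c(O)nncc12` and compound 4 `Cc1nc(C(C)C)n2c(O)nncc12` share another, and how the two cores differ is not broken down here. In a functional assay for inhibition, with Homo sapiens as the target (on this read-out higher numbers stand for weaker inhibition and lower numbers for stronger inhibition), compound 1 gives only a limit of the assay, > 48000 nM. Compound 2 likewise gives only a limit, > 48000 nM. Compound 3 gives a number, 31000 nM. Compound 1 differs from compound 2 by hydrogen in place of methyl on a saturated chain carbon bound to an aromatic nitrogen; the resulting step that the two limits leave unreadable from compound 2 to compound 1 cannot be read because the limit of > 48000 nM in this assay, at which 2 of the 3 values shown sit, leaves no number on either side. Compound 4 differs from compound 3 by hydrogen in place of methyl on a saturated chain carbon bound to an aromatic carbon and two saturated chain carbons. The two changes are the same kind of change, not the same: in one the carbon carrying the methyl is bound to an aromatic nitrogen, in the other to an aromatic carbon and two saturated chain carbons. Since the measured pair gives no size, the expectation for compound 4 rests on compound 3 alone, whose value of 31000 nM is weak. Compound 4 is expected to stay close to that, with an estimated step of a 1.3-fold higher number from compound 3 to compound 4 (0.11 log units; within the scatter). Compound 4 is therefore estimated at 40000 nM, between 15000 nM and 100000 nM.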

Compound 4, half-maximal inhibitory concentration: > 48000 nM
Compound 4: a limit, no number (the forecaster's own chance of this, stated with the estimate: 40%); middle value at least 1.2-fold (0.07 log units) from the limit.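

Trimming tert-butyl to isopropyl on the core of compound 3 gives an at least 1.5-fold higher number from compound 3 to compound 4 (0.18 log units; that floor lies within the scatter) in this assay, so this core shows no sign of stronger inhibition after the change, although the floor of the step is no larger than ordinary variation between repeats. Compound 4 gives only a limit, > 48000 nM, so the step has a floor and not a measured size. The related step on the other core cannot be read, and its methyl leaves a carbon bound to an aromatic nitrogen, so nothing here shows whether the change carries from one core to the other, because most of the data stop at one limit: the limit of > 48000 nM in this assay, at which 3 of the 4 values shown sit.

As far as these compounds go, the true size of the step on the core of compound 3 stays open, with only its floor known. Also open, from the compounds shown here alone, is whether an amine, a carboxylic acid or a longer chain in place of the methyl would give a readable number on either core.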